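A few compounds are considered here, and "the series" means these few. Any claim that something is new, unique, unknown or untested is made for them only; others in the source may bear on it.

For the measured compounds named here, the three compounds measured so far share one core and differ only in the group carried on the saturated chain carbon bound to the oxygen on the aromatic ring. Compound 1 `Cc1cc(C(=O)O)nn1Cc1cc(Br)ccc1OCc1ccccc1Cl` gives 28.8 nM in a functional assay on CHO-K1 cells for antagonist activity at prostaglandin E2 receptor EP1 subtype (Homo sapiens), read by FLIPR; on this read-out lower numbers stand for stronger inhibition and higher numbers for weaker inhibition. Compound 2 `Cc1cc(C(=O)O)nn1Cc1cc(Br)ccc1OCc1c(F)cccc1F` gives 105 nM, and compound 3 `Cc1cc(C(=O)O)nn1Cc1cc(Br)ccc1OCc1cccc(Cl)c1` gives 427 nM. Among these numbers compound 3 stands highest, with a 4.1-fold higher number from compound 2 to compound 3 (0.61 log units; beyond the scatter) and a 15-fold higher number from compound 1 to compound 3 (1.17 log units; beyond the scatter).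

Compound 4 `Cc1cc(C(=O)O)nn1Cc1cc(Br)ccc1OCc1cc(Cl)cc(Cl)c1` is made from compound 3 by one change: chloro in place of hydrogen on an aromatic carbon. Going by the values given here, none of the measured steps adds a second halogen to this part of the molecule; the steps from compound 1 to compound 3 and from compound 2 to compound 3 only show that where a chloro or fluoro sits on this six-membered ring shifts the number by a modest to large amount. The best guide is therefore the value of compound 3 itself, and the step is expected to be small, in either direction. Compound 4 is estimated at 350 nM, with a range from 100 nM to 1200 nM, which would mean an expected step of a 1.2-fold lower number from compound 3 to compound 4 (0.09 log units; within the scatter).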

Compound 4, inhibition constant: 1120 nM
The estimate for compound 4 lay 3.2-fold (0.51 log units) below the measured number, within the range that was stated.
By their numbers in this assay, from the lowest: compound 1; then compound 2; then compound 3; then compound 4.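

Adding a second chloro to the 3-chlorophenyl group gives a 2.6-fold higher number from compound 3 to compound 4 (0.42 log units; beyond the scatter) and so weakens inhibition, which shows that this ring position, meta to a chloro group, does not accept the extra atom without a loss. The 3,5-dichlorophenyl group now gives the weakest inhibition of the four, with an 11-fold higher number from compound 2 to compound 4 (1.03 log units; beyond the scatter) and with a 39-fold higher number from compound 1 to compound 4 (1.59 log units; beyond the scatter) on the same read-out. Nothing available here explains this loss.

The only added chloro shown starts from compound 3, so it remains open whether a second group on the 2-chlorophenyl ring of compound 1 would shift the number in the same direction. On these data alone, it also remains open whether a methyl or a methoxy group in the place of the new chloro would give a similar step, or whether this step is particular to chloro.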